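A Third Methoxy Group Added to Compound 2

The source may hold more compounds than are shown below. What is called first, only, known or untested is meant among the compounds shown, and "the series" means these compounds.

Three compounds share a common core and differ only in the substituted ring at one end and in one further side group. In a functional assay on HeLa cells (Homo sapiens) for cytotoxicity, read by MTT assay, with a stated time of 72 h (on this read-out higher numbers stand for weaker inhibition and lower numbers for stronger inhibition), compound 1 `COc1ccc(OC)c(/C=C/C(=O)Nc2cc3c(Nc4ccc(F)c(Cl)c4)ncnc3cc2OC)c1` gives "not determined" (no result reported). In this assay compound 3 `COc1ccc(/C=C/C(=O)Nc2cc3c(Nc4ccc(F)c(Cl)c4)ncnc3cc2OC)cc1` likewise gives "not determined" (no result reported). Going by the values given here, compound 2 `COc1ccc(/C=C/C(=O)Nc2cc3c(Nc4ccc(F)c(Cl)c4)ncnc3cc2O[C@H]2CCOC2)c(OC)c1` is thus the only one with a number: in this assay compound 2 gives 26500 nM, a high concentration that stands for weak inhibition of cell growth. Among the compounds with values here, with no second measured compound there is nothing to rank compound 2 against; it simply sets the single reference point.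

Compound 4 `COc1ccc(/C=C/C(=O)Nc2cc3c(Nc4ccc(F)c(Cl)c4)ncnc3cc2O[C@H]2CCOC2)c(OC)c1OC` is the next compound to be tested. The change from compound 2 is methoxy in place of hydrogen on an aromatic carbon so that the 2,4-dimethoxyphenyl becomes a 2,3,4-trimethoxyphenyl. Within the data shown here, no pair of measured compounds shows what such a change does here, so there is no measured step to lean on, and the expectation must stay cautious. The expected step of a 1.1-fold lower number from compound 2 to compound 4 (0.03 log units; within the scatter) lies within the usual scatter of repeated measurements and has no clear direction. On that basis compound 4 is estimated to give about 25000 nM in this assay, with a plausible range from 8000 nM to 80000 nM.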

Compound 4, half-maximal inhibitory concentration: 4830 nM
Estimate against measurement, compound 4: 5.2-fold (0.71 log units) above; measured number below the stated range.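

Adding one methoxy group to an aromatic carbon ortho to two methoxy groups, which turns the 2,4-dimethoxyphenyl into a 2,3,4-trimethoxyphenyl, gives a 5.5-fold lower number from compound 2 to compound 4 (0.74 log units; beyond the scatter) in this assay. This first measured step shows that this position on the ring is not a silent one: a change of only 2 heavy atoms, with no ring and no net charge, moves the read-out beyond the usual scatter and towards stronger inhibition of cell growth. Nothing shown here accounts for the drop in the number, so the step remains an observation without an explanation.

One step at one position cannot show whether the methoxy group itself matters or whether another group at the same place, such as a hydroxyl, an amine or a longer chain like ethoxy, would give a similar number. On these data alone, it is also open whether the same addition would have a similar effect with a different side group on the shared core, since compound 1 and compound 3 have no numbers that could be compared.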